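Methylsulfanyl for bromo on the triazole phenyl: cytotoxicity notes

The source may hold more compounds than are shown below. What is called first, only, known or untested is meant among the compounds shown, and "the series" means these compounds.

Three members of the series have results in an ADME assay on HEL cells (Homo sapiens) for cytotoxicity, read by cell counting, with a stated time of 3 days; a lower number here means that less compound is tolerated, a higher number that more compound is tolerated. Compound 1 `O=c1[nH]c(=O)n([C@H]2C[C@H](O)[C@@H](CO)O2)cc1-c1cn(-c2ccccc2)nn1` carries an unsubstituted phenyl on the triazole and gives 270000 nM. Compound 2 `CCCCc1ccc(-n2cc(-c3cn([C@H]4C[C@H](O)[C@@H](CO)O4)c(=O)[nH]c3=O)nn2)cc1` carries butyl on an aromatic carbon of that phenyl and gives 230000 nM, so the step of a 1.2-fold lower number from compound 1 to compound 2 (0.07 log units; within the scatter) stays within the scatter. Compound 3 `O=c1[nH]c(=O)n([C@H]2C[C@H](O)[C@@H](CO)O2)cc1-c1cn(-c2ccc(Br)cc2)nn1` carries bromo on an aromatic carbon, and in this assay compound 3 returns only a limit of the assay, >= 44000 nM. That limit, (the limit of >= 44000 nM in this assay, at which 1 of the 3 values shown sits), leaves a step that the limit leaves unreadable from compound 1 to compound 3 and a step that the limit leaves unreadable from compound 2 to compound 3 unreadable, so compound 3 cannot be placed against compounds 1 and 2 on the numbers shown.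

Compound 4 `CSc1ccc(-n2cc(-c3cn([C@H]4C[C@H](O)[C@@H](CO)O4)c(=O)[nH]c3=O)nn2)cc1` differs from compound 3 by methylsulfanyl in place of bromo on an aromatic carbon. Within the data shown here, no measured step covers a change away from bromo. Among the measured compounds shown here, the one readable step, a 1.2-fold lower number from compound 1 to compound 2 (0.07 log units; within the scatter), shows that a substituent at this position of the phenyl left the number within the scatter, and because the limit of >= 44000 nM in this assay, at which 1 of the 3 values shown sits, hides the size of any change at compound 3, the expectation rests on compounds 1 and 2. Compound 4 is therefore estimated to lie near them, at 200000 nM with a range of 60000 nM to 400000 nM. The step this estimate implies is a step that the limit leaves unreadable from compound 3 to compound 4, an expectation only, and the assay may again return a limit.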

Compound 4, minimum cytotoxic concentration: > 230000 nM
Compound 4: only a limit was reported; the forecaster's own chance of this, stated with the estimate: 40%; middle value at least 1.1-fold (0.06 log units) from the limit.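

With methylsulfanyl in this place, para to a large group, compound 4 joins compound 3 in returning only a limit in this assay: the limit of > 230000 nM in this assay, at which 1 of the 4 values shown sits.

Among these compounds, the one step that says anything is a number no lower from compound 2 to compound 4 (the limit leaves the size open), so methylsulfanyl in place of butyl gives no sign of less compound being tolerated on this phenyl, and this is the first result to show that for a change away from butyl.

The steps from compound 1 and from compound 3 to compound 4 cannot be read, and the bromo compound remains unplaced: the limit of >= 44000 nM in this assay, at which 1 of the 4 values shown sits.

Where compound 3 and compound 4 would fall as actual numbers remains open, so no order among the substituents can be drawn. From the compounds shown here alone, how an amine, a carboxylic acid or a chain longer than butyl would read in this place also remains open.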